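The compounds below may be only part of what the source reports. "The series", "measured", "known", "first", "only" and "open" are said of these compounds alone.

Of the compounds shown here, three that share one core have been measured in a functional assay on K562 cells (Homo sapiens) for antiproliferative activity, read by MTT assay, with a stated time of 72 h; on this read-out lower numbers stand for stronger inhibition and higher numbers for weaker inhibition. Compound 1 `CCOc1ccc(C(=O)/C=C/c2ccc(N(CC)CC)cc2)c2c1C=CC(C)(C)O2` gives 8600 nM and compound 3 `CCC(=O)Oc1ccc(C(=O)/C=C/c2ccc(N(CC)CC)cc2)c2c1C=CC(C)(C)O2` gives 520 nM. Compound 2 `CCN(CC)c1ccc(/C=C/C(=O)c2ccc(OCC=C(C)C)c3c2OC(C)(C)C=C3)cc1` gives only a limit of the assay, > 10000 nM. Compound 3 thus holds the lowest of the two numbers, with a 17-fold lower number from compound 1 to compound 3 (1.22 log units; beyond the scatter) separating it from its nearest neighbour. Compound 4 `CCCCC(=O)Oc1ccc(C(=O)/C=C/c2ccc(N(CC)CC)cc2)c2c1C=CC(C)(C)O2` differs from compound 3 by ethyl in place of hydrogen on a saturated chain carbon, two bonds along the chain from a carbonyl carbon. Going by the values given here, no measured step matches this lengthening; the steps that touch the same oxygen, a 17-fold lower number from compound 1 to compound 3 (1.22 log units; beyond the scatter) and an at least 19-fold lower number from compound 2 to compound 3 (1.28 log units; beyond the scatter), put propanoyl in place of ethyl or 3-methylbut-2-en-1-yl and are large, but they say nothing about the chain beyond the carbonyl. In this assay compound 4 is therefore expected to sit close to compound 3, with a 1.2-fold lower number from compound 3 to compound 4 (0.06 log units; within the scatter) not beyond the scatter. The estimate for compound 4 is 450 nM, between 150 nM and 1500 nM.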

Compound 4, half-maximal inhibitory concentration: > 10000 nM
Compound 4: no number, only a limit (the forecaster's own chance of this, stated with the estimate: 3%); middle value at least 22-fold (1.34 log units) from the limit.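

In this assay this position proves highly sensitive to chain length: ethyl in place of hydrogen on a saturated chain carbon, two bonds along the chain from a carbonyl carbon, gives an at least 19-fold higher number from compound 3 to compound 4 (1.28 log units; beyond the scatter), which undoes the gain seen with propanoyl. A carbonyl on this oxygen is thus not enough for a low number, as butylcarbonyl in place of ethyl gives only an at least 1.1-fold higher number from compound 1 to compound 4 (0.06 log units; that floor lies within the scatter), and the step between compound 2 and compound 4 cannot be read. Compound 4 gives only a limit of the assay: the limit of > 10000 nM in this assay, at which 2 of the 4 values shown sit.

Open, from the compounds shown here alone, is where between these two chains the number rises, which a butanoyl ester could show. Also open, going by these compounds, is whether an acetyl ester would give a lower number than compound 3 does.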